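The compounds below may be only part of what the source reports. "The series", "measured", "known", "first", "only" and "open" are said of these compounds alone.

In a functional assay on HCT-15 cells (Homo sapiens) for antiproliferative activity, read by MTT assay, with a stated time of 72 h (on this read-out higher numbers stand for weaker inhibition and lower numbers for stronger inhibition), compound 1 `CCCn1ccnc1-c1cc(OC)c(OC)c(OC)c1` gives > 100000 nM, which is a limit of the assay and not a number. Compound 2 `CCCCn1ccnc1-c1cc(OC)c(OC)c(OC)c1` gives > 100000 nM, again a limit. Compound 3 `CCCCCn1ccnc1-c1cc(OC)c(OC)c(OC)c1` gives > 100000 nM, also a limit. All three therefore share one boundary, as the limit of > 100000 nM in this assay, at which 3 of the 3 values shown sit, records, and none has a true value.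

Compound 4 `COc1cc(-c2nccn2-c2ccc(C)cc2)cc(OC)c1OC` keeps the shared core but changes the group on the nitrogen: 4-methylphenyl in place of pentyl on an aromatic nitrogen. In words, this places 4-methylphenyl in place of pentyl on an aromatic nitrogen.

The measured steps bearing on this change are the chain extensions: a step that the two limits leave unreadable from compound 1 to compound 2, a step that the two limits leave unreadable from compound 2 to compound 3 and a step that the two limits leave unreadable from compound 1 to compound 3. None of them has a readable size, and none of them brings in a ring, so they give only weak guidance for this swap.

Since compound 3 is known only as > 100000 nM, any readable number for compound 4 would mean stronger inhibition in this assay. The expected change, toward stronger inhibition and still very uncertain, is an at least 20-fold lower number from compound 3 to compound 4 (1.30 log units; beyond the scatter). A result at the same limit also remains quite possible.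

The estimated value for compound 4 is 5000 nM, with an expected range from 200 nM to 100000 nM.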

Compound 4, half-maximal inhibitory concentration: 800 nM
Compound 4: middle estimate off by 6.3-fold (0.80 log units), on the high side, within the range that was stated.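

In this assay, the aromatic nitrogen proves to be a place where a change in the group can be read: 4-methylphenyl in place of pentyl gives an at least 120-fold lower number from compound 3 to compound 4 (2.09 log units; beyond the scatter), 4-methylphenyl in place of butyl gives an at least 120-fold lower number from compound 2 to compound 4 (2.09 log units; beyond the scatter), and 4-methylphenyl in place of propyl gives an at least 120-fold lower number from compound 1 to compound 4 (2.09 log units; beyond the scatter). Each of these sizes is only a minimum set by a limit of the assay, so the true steps could be larger. The steps among the three chain compounds cannot be read, and compound 4 is the only one here with a readable number, which separates it from a group of compounds that share one boundary: the limit of > 100000 nM in this assay, at which 3 of the 4 values shown sit.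

Compound 4 brings in the aromatic ring and its methyl together, so the compounds shown cannot tell whether plain phenyl would give a similar number or whether the methyl matters. Nor do they show what cyclohexyl, a saturated ring of similar shape, or benzyl, which joins the ring to the nitrogen through a single chain carbon, would give at this nitrogen.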